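Compound 2 to compound 4: removing one side chain

The source may hold more compounds than are shown below. What is called first, only, known or untested is meant among the compounds shown, and "the series" means these compounds.

Measured so far:
- compound 1 `Cc1c(C#N)c(NCCO)nc2nc(NCCO)nc(N)c12` gives 20100 nM
- compound 2 `N#Cc1cc2c(N)nc(NCCO)nc2nc1NCCO` gives 10900 nM
- compound 3 `Cc1c(C#N)c(Nc2ccc(S(N)(=O)=O)cc2)nc2ncnc(N)c12` gives 16600 nM

In a functional assay on SNU-638 cells (Homo sapiens) for inhibition, read by sulforhodamine B assay, with a stated time of 2 days (on this read-out higher numbers stand for weaker inhibition of growth and lower numbers for stronger inhibition of growth), the value of compound 2 lies within the scatter of the values of compound 1 and of compound 3, so no order can be read between compound 2 and either of them. The next change leads to compound 4 `N#Cc1cc2c(N)ncnc2nc1NCCO` with hydrogen in place of (2-hydroxyethyl)amino on an aromatic carbon as the counted difference. In words, hydrogen takes the place of (2-hydroxyethyl)amino on an aromatic carbon between two ring nitrogen atoms.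

Among the compounds with values here, the only measured single-place step is a 1.8-fold lower number from compound 1 to compound 2 (0.27 log units; within the scatter) and it concerns a methyl group elsewhere, so it bears only indirectly. That step stays within the scatter. Compound 3 also has hydrogen on that carbon and gives 16600 nM but differs in other places too. Within the data shown here, no measured step isolates this removal, so no step beyond the scatter is expected in this assay on present evidence. The expected step is a 1.1-fold higher number from compound 2 to compound 4 (0.04 log units; within the scatter) on this reading. The estimated value for compound 4 is 12000 nM with an expected range from 5000 nM to 30000 nM for now.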

Compound 4, concentration for 50% growth inhibition: 4500 nM
Compound 4: the middle estimate sits 2.7-fold (0.43 log units) above what was measured; measured number outside the range, below it.
By their numbers in this assay, from the lowest: compound 4; then compounds 2, 3 and 1 (each within the scatter of the next).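

In this assay, within the data shown here, putting hydrogen in place of (2-hydroxyethyl)amino on the aromatic carbon between two ring nitrogen atoms gives a 2.4-fold lower number from compound 2 to compound 4 (0.38 log units; beyond the scatter), the first single-place step that lies beyond the scatter. This side chain is therefore not required for growth inhibition on the compound 2 scaffold, and the modest gain comes with its removal. Among these compounds, nothing measured so far explains this gain.

From the compounds shown here alone, whether hydrogen is the best choice at this carbon remains open, and a fluorine, a methoxy group or a longer chain such as 3-hydroxypropylamino there would test how narrow the preference is. Also open, going by these compounds, is whether the remaining (2-hydroxyethyl)amino group of compound 4 can be exchanged for a cyclic amine such as morpholine without losing growth inhibition.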